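The source may hold more compounds than are shown below. What is called first, only, known or untested is meant among the compounds shown, and "the series" means these compounds.

Measured compounds:
- Compound 1 `O=C1C2CCCN2C(=O)N1CN1CCN(c2cccc(C(F)(F)F)c2)CC1`: 3300 nM
- Compound 2 `O=C1C2CCCN2C(=O)N1CN1CCN(c2ccc(F)cc2)CC1`: 1190 nM
- Compound 3 `O=C1C2CCCCN2C(=O)N1CN1CCN(c2ccccc2)CC1`: 2080 nM

All three were tested in an assay on Cerebral cortex for binding affinity to Adrenergic receptor alpha-1 (Rattus norvegicus), read by radioligand binding; a lower number here means a stronger inhibitor, a higher number a weaker inhibitor. Compound 3 sits in the middle of these three numbers, and the numbers of compound 1 and compound 2 both lie close enough to it that neither gap exceeds the usual scatter of repeated measurements. On the numbers alone, then, the three compounds cannot be told apart with confidence.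

Compound 4 `O=C1C2CCCCN2C(=O)N1CN1CCN(c2cccc(C(F)(F)F)c2)CC1` has not yet been measured. It comes from compound 3 by a single change: trifluoromethyl in place of hydrogen on an aromatic carbon. Compound 1 carries the same trifluoromethyl group on the same ring position, but on a shared core of different size, so its number and that of compound 3 stand side by side without forming a clean one-step comparison.

For the measured compounds named here, with no measured pair showing this exact change, the expectation for compound 4 in this assay is a step of little size from compound 3, possibly none beyond the scatter, with a slight lean toward a higher number given that compound 1 gave 3300 nM. Compound 4 is therefore estimated at 2800 nM, within a range of 1200 nM to 6500 nM, which corresponds to an expected step of a 1.3-fold higher number from compound 3 to compound 4 (0.13 log units; within the scatter).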

Compound 4, inhibition constant: 3300 nM
For compound 4 the middle estimate is 1.2-fold (0.07 log units) below the measured one; measured number inside the range.
By their numbers in this assay, from the lowest: compounds 2, 3, 1 and 4 (each within the scatter of the next, the first and the last beyond it).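

Trifluoromethyl in place of hydrogen on an aromatic carbon, meta to a large group, now has its first comparison on one unchanged core in this assay. The result is a 1.6-fold higher number from compound 3 to compound 4 (0.20 log units; within the scatter), so a group of this size can stand at this position without a step that can be told apart from repeat measurements. Compound 1 gives 3300 nM and compound 4, which carries the same trifluoromethyl group on a core of different size, gives 3300 nM, the same printed number in both cases, and nothing measured here offers an explanation for the result.

This single step cannot show whether the position is insensitive to every substituent, since a methoxy group, a nitrile, an amine or a carboxylic acid in the same place could still give a step beyond the scatter. It also leaves open whether trifluoromethyl would behave in the same way on other aromatic carbons of the ring, as the compounds shown offer only this one placement of the group.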